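The source may hold more compounds than are shown below. What is called first, only, known or untested is meant among the compounds shown, and "the series" means these compounds.

For the measured compounds named here, in an ADME assay on cells (Fibroblast, Homo sapiens) for antiproliferative activity, read by sulforhodamine B assay, with a stated time of 48 h (on this read-out lower numbers stand for stronger inhibition and higher numbers for weaker inhibition), only two compounds have numbers so far. Compound 1 `CCCCCCCCCCCCCCNC(=O)[C@@H]1CSC(c2ccc(NC(C)=O)cc2)N1` gives 3600 nM, and compound 2 `CCCCCCCCCCCCCCCCNC(=O)[C@@H]1CSC(c2ccc(NC(C)=O)cc2)N1` gives 19100 nM, the higher of the two numbers and therefore the weaker inhibition. Compound 3 `CCCCCCCCCCCCCCCCNC(=O)[C@H]1CSC(c2ccc(NC(C)=O)cc2)N1` is a close relative of compound 2: the two compounds have the same atoms and bonds; at least one stereo element is drawn with a configuration in one of them and without one in the other: 1 of 2 stereo elements differ; a stereocentre at a saturated ring carbon is drawn R in compound 2 and S in compound 3. In other words, the two compounds are built identically, but a stereocentre at a saturated ring carbon is drawn R in compound 2 and S in compound 3.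

Going by the values given here, the only measured step is a 5.3-fold higher number from compound 1 to compound 2 (0.72 log units; beyond the scatter). That step concerns the saturated chain and leaves the stereocentre untouched, so it gives no direct guide to the size of the change here. Among the compounds with values here, no measured pair shows what swapping this stereocentre does in this assay. The starting expectation is therefore no shift beyond the scatter, with no firm direction, and the range has to stay wide. The expected step is a 1.1-fold lower number from compound 2 to compound 3 (0.05 log units; within the scatter). The estimated value for compound 3 is 17000 nM, with an expected range from 6000 nM to 45000 nM.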

Compound 3, half-maximal inhibitory concentration: 22600 nM
The estimate for compound 3 lay 1.3-fold (0.12 log units) below the measured number; low and high end bracket the measured number.
By their numbers in this assay, from the lowest: compound 1; then compounds 2 and 3 (each within the scatter of the next).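

In this assay, moving the stereocentre at a saturated ring carbon from R to S gives a 1.2-fold higher number from compound 2 to compound 3 (0.07 log units; within the scatter), so the two drawn forms of this long-chain compound cannot be told apart on this read-out. For the compounds shown here, this is the first information about this position, since the earlier pair changed only the length of the saturated chain and kept the stereocentre as it was; here the chain stays fixed, and the stereocentre alone does not carry the numbers beyond the usual scatter. Even so, this cannot yet be read as a clean comparison of two pure forms, and one caution stands against reading much into the match: the fact that one of compounds 2 and 3 is drawn with a defined configuration and the other without, at the place where they differ.

As far as these compounds go, whether the same indifference holds with the shorter chain of compound 1, which gives the lower number, remains open, and so does the part played by the second stereo element in these compounds. From the compounds shown here alone, it is also open how this stereocentre would behave if the long chain carried a carboxylic acid at its end, or if a free amine stood in place of the acetamide on the benzene ring.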